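Aminoalkyl in place of sec-butyl on the imide nitrogen

The source may report more compounds than this note shows. Statements on the series, on what has been measured and on what is new or still open speak of the compounds shown alone.

Measured so far:
compound 1 `CCC(C)N1C(=O)NC2(CSC3=C2C(=O)c2ccccc2C3=O)C1=O` — in a functional assay on MCF7 cells (Homo sapiens) for inhibition (a lower number here means a stronger inhibitor, a higher number a weaker inhibitor), compound 1 gives 178 nM
compound 2 `NCCN1C(=O)NC2(CSC3=C2C(=O)c2ccccc2C3=O)C1=O` — in this assay compound 2 gives 22 nM; 20 nM; 31 nM (3 entries)

Going by the values given here, compound 1 carries the only single number of its own in this assay; the repeated entries of compound 2 all lie well below it (the several entries of compound 2 in this assay, 22 nM; 20 nM; 31 nM (3 entries)). Compound 3 `NCCCCN1C(=O)NC2(CSC3=C2C(=O)c2ccccc2C3=O)C1=O` differs from compound 1 by 4-aminobutyl in place of sec-butyl on an amide-type nitrogen in a ring. Among the compounds with values here, no measured step between compounds of this kind exists, so the size of the change from compound 1 to compound 3 is uncertain; the estimate for the step is a 4.5-fold lower number from compound 1 to compound 3 (0.65 log units; beyond the scatter), toward stronger inhibition and beyond the usual scatter. Compound 3 is expected near 40 nM, with a range from 15 nM to 120 nM.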

Compound 3, half-maximal inhibitory concentration: 35 nM
Compound 3: the middle estimate sits 1.1-fold (0.06 log units) above what was measured; the range from low to high includes it.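

In this assay, going by these compounds alone, 4-aminobutyl in place of sec-butyl on this amide-type nitrogen in a ring gives a 5.1-fold lower number from compound 1 to compound 3 (0.71 log units; beyond the scatter), the first step at this position that can be read directly. Compound 3, with the longer aminoalkyl chain, gives 35 nM, a value in the same range as the entries for its shorter aminoalkyl analogue: the several entries of compound 2 in this assay, 22 nM; 20 nM; 31 nM (3 entries)

Open, on these data alone, is whether the terminal amine or the linear chain carries the step, which a plain n-butyl chain would separate. Also open, as far as these compounds go, are a dimethylamino end group, a carboxylic acid at the chain end and a longer chain such as 6-aminohexyl.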